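A few compounds are considered here, and "the series" means these few. Any claim that something is new, unique, unknown or untested is made for them only; others in the source may bear on it.

Compound 3, with the structure `COc1ccc2nc(C)cc(OCC(=O)Nc3cc(C)c(F)c(C)c3)c2c1`, is the one of the three measured compounds for which only a limit is known. In a toxicity assay on HepG2 cells (Homo sapiens) for inhibition, read by CellTiter-Glo, with a stated time of 48 h (a higher number here means a weaker inhibitor, a lower number a stronger inhibitor), compound 3 gives > 100000 nM, and this is a limit of the assay rather than a number. The two measured neighbours of compound 3 differ from it in one place each. Compound 1, with the structure `COc1ccc2nc(C)cc(OCC(=O)Nc3cccc(C)c3)c2c1`, gives 39800 nM in this assay, and the step of an at least 2.5-fold higher number from compound 1 to compound 3 (0.40 log units; beyond the scatter) follows from the change to 4-fluoro-3,5-dimethylphenyl in place of 3-methylphenyl on an amide-type nitrogen. Compound 2, with the structure `COc1ccc2nc(C)cc(OCC(=O)Nc3cc(C)c(OC)c(C)c3)c2c1`, gives 7940 nM in this assay, and the step of an at least 12-fold higher number from compound 2 to compound 3 (1.10 log units; beyond the scatter) follows from fluoro in place of methoxy on an aromatic carbon. Both steps rest on the fact that compound 3 sits at the limit, as noted in the limit of > 100000 nM in this assay, at which 1 of the 3 values shown sits.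

Compound 4, with the structure `COc1ccc2nc(C)cc(OCC(=O)Nc3ccccn3)c2c1`, differs from compound 3 by pyridin-2-yl in place of 4-fluoro-3,5-dimethylphenyl on an amide-type nitrogen. For the measured compounds named here, no measured step covers exactly this exchange; the two steps that do bear on the aryl group attached to the amide nitrogen show that such changes move the number well beyond the scatter in this assay, and in both cases compound 3 is the weaker end. The step from compound 3 to compound 4 is therefore expected to be a decrease, an at least 2.0-fold lower number from compound 3 to compound 4 (0.30 log units; that floor lies within the scatter), though a further limit cannot be ruled out. For compound 4 the estimate in this assay is 50000 nM, expected to fall between 15000 nM and 200000 nM.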

Compound 4, half-maximal inhibitory concentration: > 100000 nM
Compound 4 gave a limit, no number; the forecaster's own chance of this, stated with the estimate: 40%; middle value at least 2.0-fold (0.30 log units) away from the limit.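

With pyridin-2-yl on the amide-type nitrogen, this assay shows an at least 2.5-fold higher number from compound 1 to compound 4 (0.40 log units; beyond the scatter), and the value for compound 4 is a limit of the assay rather than a number. For the compounds shown here, the 4-fluoro-3,5-dimethylphenyl of compound 3 is therefore not the only group at this position to reach the limit: pyridin-2-yl, with fewer heavy atoms and one hydrogen-bond acceptor, does so too, whereas the 3-methylphenyl of compound 1 and the 4-methoxy-3,5-dimethylphenyl of compound 2 give numbers. The step between compound 3 and compound 4 cannot be read, and neither can be ranked against the other, for both stand at the same limit: the limit of > 100000 nM in this assay, at which 2 of the 4 values shown sit.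

The compounds shown do not separate the ring nitrogen of pyridin-2-yl from the loss of the methyl group, as plain phenyl, which would lie in between, is not among them. They also leave open whether pyridin-3-yl or pyridin-4-yl, or a phenyl ring carrying an amine or a carboxylic acid, would give a number in this assay or stay at the limit.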